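Replacing a Methoxyphenyl by a Nitrophenyl on the Shared Core

The source may hold more compounds than are shown below. What is called first, only, known or untested is meant among the compounds shown, and "the series" means these compounds.

compound 1 `COc1ccccc1C(C1=C(O)C(=O)c2ccccc2C1=O)c1c[nH]c2ccccc12`: > 200000 nM
compound 2 `O=C1C(O)=C(C(c2ccccc2)c2c(-c3ccccc3)[nH]c3ccccc23)C(=O)c2ccccc21`: 5180 nM
compound 3 `Cc1[nH]c2ccccc2c1C(C1=C(O)C(=O)c2ccccc2C1=O)c1ccc(Cl)cc1`: 14300 nM

In a functional assay on ECa-109 cells (Homo sapiens) for cytotoxicity, read by MTT assay, with a stated time of 48 h (a higher number here means a weaker inhibitor, a lower number a stronger inhibitor), compound 1 stands at a limit and not at a number, since (the limit of > 200000 nM in this assay, at which 1 of the 3 values shown sits). Compound 2 and compound 3 give measured values in this assay, so the shared core can reach measurable inhibition with other groups on the chain carbon. Compound 4 `O=C1C(O)=C(C(c2ccc([N+](=O)[O-])cc2)c2c[nH]c3ccccc23)C(=O)c2ccccc21` carries 4-nitrophenyl in place of 2-methoxyphenyl on a saturated chain carbon bound to an aromatic carbon and a double-bonded ring carbon. Among the measured compounds shown here, no measured step covers this change, so the account rests on the spread among compound 1, compound 2 and compound 3, and a move toward stronger inhibition in this assay is expected, though its size is uncertain and a second limit remains possible. Compound 4 is estimated at 30000 nM, with a range from 6000 nM to 200000 nM. The estimated step of an at least 6.6-fold lower number from compound 1 to compound 4 (0.82 log units; beyond the scatter) expresses this expectation.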

Compound 4, half-maximal inhibitory concentration: 60900 nM
Compound 4: middle estimate off by 2.0-fold (0.31 log units), on the low side; the range from low to high includes it.
By their numbers in this assay, from the lowest: compound 2; then compound 3; then compound 4. At a limit, above all of these: compound 1.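

In this assay, 4-nitrophenyl in place of 2-methoxyphenyl on a saturated chain carbon bound to an aromatic carbon and a double-bonded ring carbon gives an at least 3.2-fold lower number from compound 1 to compound 4 (0.51 log units; beyond the scatter), so on an otherwise unchanged shared core this position alone can move the read-out. The true size of that step stays unknown, since the value for compound 1 is a limit and not a number: the limit of > 200000 nM in this assay, at which 1 of the 4 values shown sits.

As far as these compounds go, it remains open whether the change comes from losing 2-methoxyphenyl or from gaining 4-nitrophenyl. From the compounds shown here alone, it also remains open whether an aminophenyl or a carboxyphenyl on the same saturated chain carbon would give a lower number.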